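This account rests on a few compounds, and the source may have more. Where it says the series, first, only, none or still open, it means among the compounds named here.

Measured so far in a functional assay on NCI-H661 cells (Homo sapiens) for antiproliferative activity, read by MTT assay, with a stated time of 72 h; a higher number here means a weaker inhibitor of growth, a lower number a stronger inhibitor of growth:

Compound 1, `O=C(COc1ccc2c(=O)c(-c3ccccc3)coc2c1)Nc1ccccc1`, gives > 10000 nM, which is a limit of this assay rather than a number.
Compound 2, `O=C(COc1ccc2c(=O)c(-c3ccccc3)coc2c1)Nc1ccc(F)cc1`, gives > 10000 nM, again a limit of this assay.
Compound 3, `COc1ccc(NC(=O)COc2ccc3c(=O)c(-c4ccccc4)coc3c2)cc1`, gives 9530 nM.

Within the data shown here, compound 3 therefore stands as the only compound with a measured number; the two others sit at the limit of this assay, as the limit of > 10000 nM in this assay, at which 2 of the 3 values shown sit, records. All three share one core and differ only in the group on the aniline ring attached to the amide.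

The next compound, compound 4, `O=C(COc1ccc2c(=O)c(-c3ccccc3)coc2c1)Nc1ccc(-c2ccccc2)cc1`, carries a different group at that place: phenyl in place of methoxy on an aromatic carbon.

The measured steps that bear on this place are an at least 1.0-fold lower number from compound 1 to compound 3 (0.02 log units; that floor lies within the scatter) and an at least 1.0-fold lower number from compound 2 to compound 3 (0.02 log units; that floor lies within the scatter); both are floors that lie within the scatter, so neither shows a real change. The step that the two limits leave unreadable from compound 1 to compound 2 is unreadable because both values are limits. Nothing seen here points to a large effect from swapping the group at this place, so for compound 4 a step of a 1.1-fold lower number from compound 3 to compound 4 (0.02 log units; within the scatter) in this assay is expected, that is, no change beyond the scatter, with a fair chance that only a limit is reported. Compound 4 is estimated at 9000 nM, within a range from 3000 nM to 30000 nM.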

Compound 4, concentration for 50% growth inhibition: > 10000 nM
Compound 4: only a limit was reported (the forecaster's own chance of this, stated with the estimate: 45%); at least 1.1-fold (0.04 log units) between middle value and limit.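

In this assay, phenyl in place of methoxy gives an at least 1.0-fold higher number from compound 3 to compound 4 (0.02 log units; that floor lies within the scatter), so adding this larger ring at this place brings no readable gain, and the limit gives no size for any loss. The steps to compound 4 from compound 1 and compound 2 cannot be read, as each joins two limits. Hydrogen, fluoro, methoxy and phenyl at this place thus all leave the series close to one mark in this assay: the limit of > 10000 nM in this assay, at which 3 of the 4 values shown sit.

Still open, on these data alone, is whether any group at this place can bring the value well clear of that limit, as an amine or a carboxylic acid might or might not do. The compounds shown also leave unanswered what a longer chain in place of the methoxy would do.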